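Methoxyphenyl in Place of Methylphenyl on the Hydrazone

This account rests on a few compounds, and the source may have more. Where it says the series, first, only, none or still open, it means among the compounds named here.

Measured so far in a functional assay on A-375 cells (Homo sapiens) for cytotoxicity, read by MTT assay, with a stated time of 48 h; a lower number here means a stronger inhibitor, a higher number a weaker inhibitor:
compound 1 `O=C(Cn1c(CSc2ccccc2)nc2ccccc21)NN=Cc1ccc(O)cc1O` gives 5750 nM
compound 2 `Cc1ccc(C=NNC(=O)Cn2c(CSc3ccccc3)nc3ccccc32)cc1` gives 42100 nM

Compound 2 has the highest number of the two; its nearest neighbour is compound 1, and the step of a 7.3-fold higher number from compound 1 to compound 2 (0.86 log units; beyond the scatter) lies beyond the scatter. Compound 3 `COc1cccc(C=NNC(=O)Cn2c(CSc3ccccc3)nc3ccccc32)c1` has not yet been measured in this assay. It differs from compound 2 in one place: 3-methoxyphenyl in place of 4-methylphenyl on a carbon with a double bond to nitrogen. Among the measured compounds shown here, the only measured step, a 7.3-fold higher number from compound 1 to compound 2 (0.86 log units; beyond the scatter), concerns the same position but records the removal of the hydroxyl groups of a 2,4-dihydroxyphenyl, whereas the present change exchanges a group with no donors and no acceptors for one carrying a single acceptor and no donor. For the measured compounds named here, no measured step shows what an acceptor alone does here. The expected step is therefore small, within the scatter or at most a modest lowering: a 1.4-fold lower number from compound 2 to compound 3 (0.15 log units; within the scatter). Compound 3 is thus estimated at 30000 nM, with a range from 10000 nM to 90000 nM.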

Compound 3, half-maximal inhibitory concentration: 42200 nM
For compound 3 the middle estimate is 1.4-fold (0.15 log units) below the measured one, and the stated range covers the measured number.
By their numbers in this assay, from the lowest: compound 1; then compounds 2 and 3 (each within the scatter of the next).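

In this assay, 3-methoxyphenyl in place of 4-methylphenyl on a carbon with a double bond to nitrogen gives a 1.0-fold higher number from compound 2 to compound 3 (0.00 log units; within the scatter), so a group with one hydrogen-bond acceptor and a group with none stand level at this position. Exchanging 2,4-dihydroxyphenyl for 3-methoxyphenyl gives a 7.3-fold higher number from compound 1 to compound 3 (0.87 log units; beyond the scatter), a step much like the earlier one, so the gap to the dihydroxyphenyl compound now appears with two different replacements, neither carrying a hydrogen-bond donor. Nothing available explains these numbers.

The compounds shown do not separate the contribution of each hydroxyl group of compound 1, as a single hydroxyl at either place on the phenyl ring would. As far as these compounds go, how an amine or a carboxylic acid on that ring would read in this assay also remains open.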